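A Bridged Amino Ester Loses Its Nitrogen Methyl

A few compounds are considered here, and "the series" means these few. Any claim that something is new, unique, unknown or untested is made for them only; others in the source may bear on it.

Compound 1 `COC(=O)C1CC2CC1N(C)C2`: 4.2
Compound 2 `COC(=O)[C@@H]1C[C@@H]2C[C@H]1N(C)C2`: < 4, a limit
Compound 3 `COC(=O)[C@H]1C[C@H]2C[C@@H]1N(C)C2`: 4.9

In a functional assay (ileum) with Cavia porcellus as the target (a lower number here means a less potent compound, a higher number a more potent compound, by a factor of ten per unit of this negative logarithm), compound 1 gives 4.2. Compound 2 reaches only a limit of the assay, < 4, so its number is not known. Compound 3 gives 4.9, the highest of the two numbers, with compound 1 as its nearest neighbour below it.

The measured steps all concern configuration rather than substitution. The step of a number 0.70 log units higher from compound 1 to compound 3 (beyond the scatter) and the step of a number at least 0.20 log units lower from compound 1 to compound 2 (that floor lies within the scatter) each compare a compound drawn with configuration to one drawn without the fact that one of compounds 1 and 2 is drawn with a defined configuration and the other without, at the place where they differ (the fact that one of compounds 1 and 3 is drawn with a defined configuration and the other without, at the place where they differ), and the step of a number at least 0.90 log units higher from compound 2 to compound 3 (beyond the scatter) compares mirror images (the fact that compounds 2 and 3 differ only in the configuration as drawn).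

Compound 4 `COC(=O)[C@H]1C[C@@H]2CN[C@H]1C2` differs from compound 3 by hydrogen in place of methyl on an amine nitrogen in a ring. Among the measured compounds shown here, no measured step touches the amine nitrogen or any substituent at all, so none of them bears on this change, and the data give no direction for it. Compound 4 is therefore expected to sit near compound 3, with a step of a number 0.30 log units lower from compound 3 to compound 4 (within the scatter) that need not exceed the scatter, and a wide range is needed. The estimate for compound 4 is 4.6, expected to lie between 3.8 and 5.4.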

Compound 4, negative logarithm of the half-maximal effective concentration: 5.2
The estimate for compound 4 lay 0.60 log units below the measured number; the measured number falls inside the stated range.
By their numbers in this assay, from the lowest: compound 1; then compounds 3 and 4 (each within the scatter of the next). At a limit, below all of these: compound 2.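

In this assay, among the compounds shown here, this is the first change in the set that touches a substituent rather than a configuration: on the amine nitrogen in a ring, hydrogen takes the place of methyl, and the outcome is a number 0.30 log units higher from compound 3 to compound 4 (within the scatter) as the only step that bears on this position. Read with that scatter in mind, the methyl group can leave this nitrogen without a change that repeated measurement could separate, so the number seen for compound 3 does not depend on that methyl in any way these data can detect. The evidence at hand concerns configuration and the assay limit and offers no explanation for this step at the nitrogen.

Still open, going by these compounds, is whether a larger group on the same nitrogen, such as an ethyl, a benzyl or an acetyl, would stay in the same range or move clearly away from it. Also open, on these data alone, is whether the mirror image of compound 4 would show a gap like a number at least 0.90 log units higher from compound 2 to compound 3 (beyond the scatter) in the methyl series, and whether a carboxylic acid or an amide could stand in place of the methyl ester on the shared core.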